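A few compounds are considered here, and "the series" means these few. Any claim that something is new, unique, unknown or untested is made for them only; others in the source may bear on it.

Measured compounds in an in vitro assay on HEK-tsA201 cells for antagonist activity at Neuronal acetylcholine receptor; alpha3/beta4 (Homo sapiens), read by fluorescence and calcium flux; on this read-out higher numbers stand for weaker inhibition and lower numbers for stronger inhibition:
- compound 1 `CCCOc1ccc(C(=O)Nc2cccc(Cl)n2)cc1`: > 100000 nM, a limit of the assay rather than a number
- compound 2 `CCCOc1ccc(C(=O)Nc2cccc(CC)n2)cc1`: 29200 nM

Among the measured compounds shown here, compound 2 thus carries the only numerical value in this assay; the other entry, that of compound 1, is a limit (the limit of > 100000 nM in this assay, at which 1 of the 2 values shown sits).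

Compound 3 `CCCCNc1cccc(NC(=O)c2ccc(OCCC)cc2)n1` is not yet measured. It differs from compound 2 by butylamino in place of ethyl on an aromatic carbon.

For the measured compounds named here, the one measured step at this same position, an at least 3.4-fold lower number from compound 1 to compound 2 (0.53 log units; beyond the scatter), shows that changing the group next to the ring nitrogen can move the number beyond the scatter. Going by the values given here, there is no measured step in which an amino group replaces an alkyl group, so the direction for compound 3 is not fixed by the data; a modest move is as plausible as none.

Compound 3 is estimated at 15000 nM, range 4000 nM to 60000 nM. This estimate corresponds to an expected step of a 1.9-fold lower number from compound 2 to compound 3 (0.29 log units; within the scatter).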

Compound 3, half-maximal inhibitory concentration: 77800 nM
Beside the measured number, compound 3's estimate is 5.2-fold (0.71 log units) below it; measured number outside the range, above it.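

The position next to the ring nitrogen now has a measured step in which butylamino replaces an alkyl group, and it runs towards weaker inhibition: a 2.7-fold higher number from compound 2 to compound 3 (0.43 log units; beyond the scatter). Among the compounds shown here, of the three compounds, compound 2 therefore keeps the lowest number, and ethyl is the only group here with a step beyond the scatter from chloro. The comparison with chloro gives no such result for butylamino: an at least 1.2-fold lower number from compound 1 to compound 3 (0.10 log units; that floor lies within the scatter). Compound 1 stands at > 100000 nM, which is a limit and not a number.

Butylamino differs from ethyl in both its linking nitrogen and its chain length, and the compounds shown do not separate the two. Ethylamino, with the chain of compound 2 on a nitrogen, or pentyl, a longer chain without one, would bear on that question.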